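The source may hold more compounds than are shown below. What is called first, only, known or untested is meant among the compounds shown, and "the series" means these compounds.

Measured compounds in a functional assay on HL-60 cells (Homo sapiens) for antiproliferative activity, read by MTT assay, with a stated time of 72 h; a lower number here means a stronger inhibitor, a higher number a weaker inhibitor:
compound 1, `CN(C(=O)c1ccc(Cl)cc1)c1ccc2[nH]c(-c3n[nH]c4ccccc34)cc2n1`: 450 nM
compound 2, `Cc1ccc(S(=O)(=O)N(C)c2ccc3[nH]c(-c4n[nH]c5ccccc45)cc3n2)cc1`: 3030 nM

Compound 2 stands with the higher of the two numbers in this assay. Among the measured compounds shown here, the only step measured, a 6.7-fold higher number from compound 1 to compound 2 (0.83 log units; beyond the scatter), concerns the group on the ring nitrogen and does not touch the aryl substituent. Compound 3, `COc1ccc(S(=O)(=O)N(C)c2ccc3[nH]c(-c4n[nH]c5ccccc45)cc3n2)cc1`, differs from compound 2 by methoxy in place of methyl on an aromatic carbon of a six-membered aromatic ring of carbon only. For the measured compounds named here, no measured step bears on this change, so a step expected for compound 3 is one within the scatter, a 1.0-fold lower number from compound 2 to compound 3 (0.00 log units; within the scatter). Compound 3 is therefore estimated at 3000 nM, with a range of 1200 nM to 8000 nM.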

Compound 3, half-maximal inhibitory concentration: 4340 nM
The estimate for compound 3 lay 1.4-fold (0.16 log units) below the measured number, within the range that was stated.
By their numbers in this assay, from the lowest: compound 1; then compounds 2 and 3 (each within the scatter of the next).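

In this assay the change from 4-methylphenyl to 4-methoxyphenyl gives a 1.4-fold higher number from compound 2 to compound 3 (0.16 log units; within the scatter) at the aromatic carbon para to a large group. Within this sulfonyl pair, methoxy and methyl therefore cannot be told apart at this position, even with the added oxygen and hydrogen-bond acceptor. Nothing available gives a reason for this result.

Open, as far as these compounds go, is whether an amine, a carboxylic acid or a longer alkoxy chain at this position would move the number beyond the scatter. Also open, from the compounds shown here alone, is whether methoxy would behave the same way in the carbonyl compound 1.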